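The compounds below may be only part of what the source reports. "The series", "measured", "known", "first", "only" and "open" are said of these compounds alone.

Compound 1 `COC(=O)c1c(C)[nH]c(C)c1C(=O)c1ccccc1C` and compound 2 `COC(=O)c1c(C)[nH]c(C)c1C(=O)c1ccccc1Br` share one core and differ only in the group on an aromatic carbon. In a functional assay with Cavia porcellus as the target (a lower number here means that less compound is needed, a higher number that more compound is needed for the effect), compound 1 gives 9470 nM, and compound 2 gives 8950 nM. The step of a 1.1-fold lower number from compound 1 to compound 2 (0.02 log units; within the scatter) changed nothing beyond the scatter. Compound 2 therefore stands with the lowest of the two numbers, yet compound 1 lies within the scatter of it, so no order can be read between the two. Compound 3 `COC(=O)c1c(C)[nH]c(C)c1C(=O)c1ccccc1C(F)(F)F` differs from compound 2 by trifluoromethyl in place of bromo on an aromatic carbon, placed on an aromatic carbon of a six-membered aromatic ring of carbon only, ortho to a large group. Going by the values given here, the only measured step at this place was flat, and no other step bears on it, so the expected step of a 1.0-fold higher number from compound 2 to compound 3 (0.00 log units; within the scatter) in this assay is none beyond the scatter. Compound 3 is thus estimated at 9000 nM, with a range from 4000 nM to 20000 nM.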

Compound 3, half-maximal effective concentration: 4840 nM
The estimate for compound 3 lay 1.9-fold (0.27 log units) above the measured number; the measured number falls inside the stated range.
By their numbers in this assay, from the lowest: compounds 3, 2 and 1 (each within the scatter of the next).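

At this place, on an aromatic carbon of a six-membered aromatic ring of carbon only, ortho to a large group, trifluoromethyl now joins methyl and bromo: in this assay there is a 1.8-fold lower number from compound 2 to compound 3 (0.27 log units; within the scatter) and, measured against methyl, a 2.0-fold lower number from compound 1 to compound 3 (0.29 log units; within the scatter) as well. Even the exchange of bromo for trifluoromethyl, which brings 4 heavy atoms where 1 stood, thus stays inside the scatter, so no order can be read from either step and the three groups cannot be told apart at this place. Nothing available accounts for the values of these compounds. On these data alone, it remains open whether an amine, a carboxylic acid or a methoxy group at this place would move the number beyond the scatter. Also open, as far as these compounds go, is how an amide in place of the methyl ester on the shared core would read in this assay when paired with any of these three groups.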